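The source may report more compounds than this note shows. Statements on the series, on what has been measured and on what is new or still open speak of the compounds shown alone.

Measured compounds:
compound 1, `CCCCCCCCc1ccc(OCC(=O)Cn2nnc(-c3ccc(Cl)cc3)n2)cc1`, 74%
compound 2, `CCCCCCCCc1ccc(OCC(=O)Cn2nnc(-c3cccc(Cl)c3)n2)cc1`, 69%
compound 3, `CCCCCCCCc1ccc(OCC(=O)Cn2nnnc2-c2ccc(Cl)cc2)cc1`, 45%

In an ADME assay on S9 fraction from liver (Rattus norvegicus) for metabolic stability, read by LC-MS, using NADPH, with a stated time of 30 min (on this read-out higher numbers stand for a more stable compound and lower numbers for a less stable compound), the three measured compounds fall into two groups. Compound 1 and compound 2 share one core, and the change between them, (3-chlorophenyl in place of 4-chlorophenyl on an aromatic carbon), gives a number 5 percentage points lower from compound 1 to compound 2 (within the scatter). Compound 3 has a different core; how the two cores differ is not broken down here. Compound 3 stands lowest of the three, and its gap to compound 2 and to compound 1 lies beyond the scatter.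

Compound 4, `CCCCCCCCc1ccc(OCC(=O)Cn2nnnc2-c2cccc(Cl)c2)cc1`, is not yet measured. It arises from compound 3 by 3-chlorophenyl in place of 4-chlorophenyl on an aromatic carbon. This is the same kind of change as that from compound 1 to compound 2, though the surroundings differ: in compound 3 the place is next to the ring atom that bears a large group, whereas in compound 1 it is two ring bonds from the ring atom that bears a large group. Since the earlier step was a number 5 percentage points lower from compound 1 to compound 2 (within the scatter), a step of similar size is expected here, namely a number 3 percentage points lower from compound 3 to compound 4 (within the scatter). Compound 4 is therefore estimated at 42%, with a range from 30% to 55%.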

Compound 4, percent of the compound remaining: 41%
Compound 4: middle estimate off by 1 percentage points, on the high side, and the stated range covers the measured number.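

In this assay, 3-chlorophenyl in place of 4-chlorophenyl on the core of compound 3 gives a number 4 percentage points lower from compound 3 to compound 4 (within the scatter), and this sits closely with the step seen on the other core. Set side by side, the two steps show no difference between the cores: the same change on two cores in this assay, a number 5 percentage points lower (within the scatter) from compound 1 to compound 2 and a number 4 percentage points lower (within the scatter) from compound 3 to compound 4, 1 percentage points apart, within the scatter of two such steps. This shows that, in this read-out, the change leaves the number within the usual scatter on both cores, but since neither step stands clear of the scatter, it does not show a real effect being transferred, and two cores cannot establish that the same would hold on any further core in the series.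

On these data alone, the four compounds all carry a chlorophenyl group, so it stays open how a nitrile, a methoxy group or a carboxylic acid in the place of the chlorine would read on either core. Also open, as far as these compounds go, is what a shorter chain in place of the long alkyl chain, or an alcohol in place of the carbonyl, would do to these numbers.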